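Rat microsomal clearance across para substituents on the shared core

The compounds below may be only part of what the source reports. "The series", "measured", "known", "first", "only" and "open" are said of these compounds alone.

Compound 1, `CC#C[C@H]1CN(S(=O)(=O)c2ccc(N)nc2)CCN1c1ccc(C(=O)NC)cc1`, gives 41 mL.min-1.g-1 in an ADME assay (liver) for metabolic stability, with Liver microsome (Rattus norvegicus) as the target, using microsomes and NADPH, with a stated time of 30 min; a lower number here means slower removal, a higher number faster removal of the compound.
Compound 2, `CC#C[C@H]1CN(S(=O)(=O)c2ccc(N)nc2)CCN1c1ccc(C(O)(CC#N)C(F)(F)F)cc1`, gives 57 mL.min-1.g-1 in this assay.
Compound 3, `CC#C[C@H]1CN(S(=O)(=O)c2ccc(N)nc2)CCN1c1ccc([S+](C)[O-])cc1`, gives 17 mL.min-1.g-1 in this assay.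

Compound 3 carries the lowest of the three numbers in this assay: a 2.4-fold lower number from compound 1 to compound 3 (0.38 log units; beyond the scatter) and a 3.4-fold lower number from compound 2 to compound 3 (0.53 log units; beyond the scatter), both beyond the scatter, while a 1.4-fold higher number from compound 1 to compound 2 (0.14 log units; within the scatter) is within it. Compound 4, `CC#C[C@H]1CN(S(=O)(=O)c2ccc(N)nc2)CCN1c1ccc(S(N)(=O)=O)cc1`, differs from compound 3 by a group of 4 heavy atoms (1 nitrogen, 2 oxygen, 1 sulfur; no ring) in place of a group of 3 heavy atoms (1 carbon, 1 oxygen, 1 sulfur; no ring), on an aromatic carbon. Within the data shown here, no measured step introduces a sulfamoyl, so the two steps ending at compound 3 are the only guide, and they show that the group leaving is associated with the lowest number of the set. The step in this assay is therefore expected to be small, with a slight lean upward, roughly a 1.3-fold higher number from compound 3 to compound 4 (0.11 log units; within the scatter). For compound 4 the estimate in this assay is 22 mL.min-1.g-1, with a range of 10 mL.min-1.g-1 to 48 mL.min-1.g-1.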

Compound 4, intrinsic clearance in microsomes: 30 mL.min-1.g-1
Compound 4: middle estimate off by 1.4-fold (0.13 log units), on the low side; the measured number falls inside the stated range.
By their numbers in this assay, from the lowest: compounds 3, 4, 1 and 2 (each within the scatter of the next, the first and the last beyond it).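

In this assay, sulfamoyl on this aromatic carbon gives a 1.8-fold higher number from compound 3 to compound 4 (0.25 log units; within the scatter), a 1.9-fold lower number from compound 2 to compound 4 (0.28 log units; within the scatter) and a 1.4-fold lower number from compound 1 to compound 4 (0.14 log units; within the scatter). Compound 4 therefore lies within the scatter of all three earlier compounds, whereas compound 3 lies beyond it from both compound 1 and compound 2. No available evidence accounts for these steps. As far as these compounds go, how an amine or a carboxylic acid at this position would read in this assay remains open. So does the effect of a methyl group on the sulfamoyl nitrogen.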